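The source may report more compounds than this note shows. Statements on the series, on what has been measured and on what is new or still open speak of the compounds shown alone.

Within the data shown here, compound 2 `Cc1ccc(OCC(=O)N(Cc2cccs2)c2ccn[nH]2)cc1` stands lowest of the two numbers so far in an assay on HEK293 cells for agonist activity at transient receptor potential cation channel subfamily M member 8 (Homo sapiens), read by fluorescence and calcium flux, with a stated time of 15 min (a higher number here means that more compound is needed for the effect, a lower number that less compound is needed), at 0.2 nM; the only comparator, compound 1 `Cc1ccc(OCC(=O)N(Cc2cccs2)c2ccncc2)cc1`, gives 52 nM, and the step is a 260-fold lower number from compound 1 to compound 2 (2.41 log units; beyond the scatter). Compound 3 `Cc1ccc(OCC(=O)N(Cc2cccs2)c2ncccn2)cc1` is not yet measured; the change is pyrimidin-2-yl in place of 1H-pyrazol-5-yl on an amide-type nitrogen. Among the measured compounds shown here, the single measured step bears on this in reverse: the five-membered ring with its hydrogen-bond donor leaves, and a six-membered ring enters, recalling the pyridin-4-yl of compound 1. The number for compound 3 is therefore expected to rise, a 150-fold higher number from compound 2 to compound 3 (2.18 log units; beyond the scatter). The estimate for compound 3 is 30 nM, range 5 nM to 200 nM.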

Compound 3, half-maximal effective concentration: 3700 nM
The estimate for compound 3 lay 120-fold (2.09 log units) below the measured number; measured number outside the range, above it.
By their numbers in this assay, from the lowest: compound 2; then compound 1; then compound 3.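

In this assay, the group on the amide-type nitrogen is not settled by ring size alone: two six-membered aromatic rings are separated by a 71-fold higher number from compound 1 to compound 3 (1.85 log units; beyond the scatter). The loss of 1H-pyrazol-5-yl for pyrimidin-2-yl gives a 19000-fold higher number from compound 2 to compound 3 (4.27 log units; beyond the scatter), so this place spans a very wide range of numbers within three compounds. Nothing available gives a reason for either step. The compounds shown leave open whether the low number of compound 2 goes with the hydrogen-bond donor or with the five-membered ring, as the two always leave together. A 1-methylpyrazol-5-yl group on the amide-type nitrogen would separate them.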